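The source may hold more compounds than are shown below. What is called first, only, known or untested is meant among the compounds shown, and "the series" means these compounds.

Measured compounds:
- compound 1 `Nc1ccc2cccc(OCCC(F)(F)F)c2n1`: 722 nM
- compound 2 `CCC(C)COc1cccc2ccc(N)nc12`: 36 nM
- compound 3 `CC#CCCOc1cccc2ccc(N)nc12`: > 2000 nM

In an assay on cells with melanin-concentrating hormone receptor 1 (Homo sapiens) as the target, read by radioligand binding (a higher number here means a weaker inhibitor, a lower number a stronger inhibitor), compound 1 gives 722 nM and compound 2 gives 36 nM. Compound 3 gives only a limit of the assay, > 2000 nM, so its true number is not known (the limit of > 2000 nM in this assay, at which 1 of the 3 values shown sits). Compound 3 therefore stands at the weak end of the three.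

Compound 4 `COC(C)(C)CCOc1cccc2ccc(N)nc12` is the next step: 1-methoxy-1-methylethyl in place of prop-1-yn-1-yl on a saturated chain carbon, two bonds along the chain from an oxygen on an aromatic ring.

Among the measured compounds shown here, two measured steps bear on this. Going an at least 2.7-fold higher number from compound 1 to compound 3 (0.44 log units; beyond the scatter), and going an at least 55-fold higher number from compound 2 to compound 3 (1.74 log units; beyond the scatter). Both moves onto the triple-bond chain worsened binding, the second one strongly, and the sec-butyl chain of compound 2 gave the best number seen. Compound 4 swaps the triple bond for a branched, oxygen-bearing saturated group, so a return toward the stronger side is expected.

Compound 4 is therefore estimated at 200 nM, within 40 nM to 1000 nM, an expected step of an at least 10-fold lower number from compound 3 to compound 4 (1.00 log units; beyond the scatter).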

Compound 4, half-maximal inhibitory concentration: 132 nM
Compound 4: middle estimate off by 1.5-fold (0.18 log units), on the high side; measured number inside the range.
By their numbers in this assay, from the lowest: compound 2; then compound 4; then compound 1. At a limit, above all of these: compound 3.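

In this assay, a branched saturated group carrying an oxygen is accepted on this chain carbon, with an at least 15-fold lower number from compound 3 to compound 4 (1.18 log units; beyond the scatter). The value of compound 3 is a limit of the assay: the limit of > 2000 nM in this assay, at which 1 of the 4 values shown sits.

The same group also improves on trifluoromethyl, with a 5.5-fold lower number from compound 1 to compound 4 (0.74 log units; beyond the scatter), but the 2-methoxy-2-methylpropyl chain does not match sec-butyl, with a 3.7-fold higher number from compound 2 to compound 4 (0.56 log units; beyond the scatter), so an oxygen in the chain is compatible with good binding without giving the best number shown.

The compounds shown leave open whether the oxygen or the branching matters more, as no pair here changes one without the other. A tert-butyl group in the same place, with only carbon in place of the methoxy group, would separate the two, and a dimethylamino group would show whether another heteroatom can stand in for that oxygen.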